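The source may report more compounds than this note shows. Statements on the series, on what has been measured and on what is new or still open speak of the compounds shown alone.

Compound 1 `CCOC(=O)N1CCN(CCCOc2ccc(-c3cccc(C#N)c3)cc2)CC1`: 24000 nM
Compound 2 `N#Cc1ccc(-c2ccc(OCCCN3CCCC3)cc2)cc1`: 67600 nM

The measurements come from an assay on isolated protein for binding affinity to histamine H2 receptor (Homo sapiens); on this read-out higher numbers stand for weaker inhibition and lower numbers for stronger inhibition. In this assay compound 1 gives 24000 nM and compound 2 gives 67600 nM. Of the two numbers, compound 1 has the lower one, and its gap to compound 2 lies beyond the usual scatter of repeated measurements, so compound 1 is the stronger binder of the pair. Both values, however, sit in a range that counts as weak binding.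

Compound 3 `CCOC(=O)N1CCN(CCCOc2ccc(-c3ccc([N+](=O)[O-])cc3)cc2)CC1` has not yet been measured. It keeps the whole core of compound 1 and changes one group: 4-nitrophenyl in place of 3-cyanophenyl on an aromatic carbon. The new group sits on an aromatic carbon of a six-membered aromatic ring of carbon only, para to a large group. Going by the values given here, no pair of measured compounds shows what this exact change does, so no step of known size can be drawn on. With both anchors already weak, the expectation is a step of no size beyond the scatter, in either direction. Compound 3 is therefore estimated at 30000 nM, within a range from 8000 nM to 110000 nM, which corresponds to an expected step of a 1.3-fold higher number from compound 1 to compound 3 (0.10 log units; within the scatter).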

Compound 3, inhibition constant: 8320 nM
The estimate for compound 3 lay 3.6-fold (0.56 log units) above the measured number; the range from low to high includes it.
By their numbers in this assay, from the lowest: compound 3; then compound 1; then compound 2.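

Going by these compounds alone, the swap of 3-cyanophenyl for 4-nitrophenyl on an aromatic carbon gives a 2.9-fold lower number from compound 1 to compound 3 (0.46 log units; beyond the scatter) in this assay and is the first step here that changes only one place, so it shows that the number responds to what this outer aromatic ring carries. The step is modest and lies beyond the scatter, yet compound 3 at 8320 nM still counts as a weak binder, so this change improves the number without altering that overall picture. Nothing measured here explains the step.

The swap also changes both the attached group, nitrile to nitro, and its place on the ring, as the names 3-cyanophenyl and 4-nitrophenyl show, and this single step cannot separate those two changes. As far as these compounds go, it remains open what a plain phenyl, or a phenyl carrying an amine or a carboxylic acid, would give on the core of compound 1, and whether any group at this place could lift the binding out of the weak range.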